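The compounds below may be only part of what the source reports. "The series", "measured", "known", "first", "only" and "open" are said of these compounds alone.

Measured so far in a functional assay on NCI-H460 cells (Homo sapiens) for cytotoxicity, read by MTT assay, with a stated time of 72 h; on this read-out higher numbers stand for weaker inhibition and lower numbers for stronger inhibition:
- compound 1 `CN(C)CCn1cnnc1-c1cc(Oc2ccc(NC(=O)N/N=C/c3ccc(Cl)cc3Cl)cc2F)ccn1` gives 130 nM
- compound 2 `CN(C)CCn1cnnc1-c1cc(Oc2ccc(NC(=O)N/N=C/c3ccccc3)cc2F)ccn1` gives 1780 nM
- compound 3 `CN(C)CCn1cnnc1-c1cc(Oc2ccc(NC(=O)N/N=C/c3ccc(F)cc3)cc2F)ccn1` gives 1980 nM

Compound 3 holds the highest of the three numbers in this assay. Its gap to compound 2 is small, a 1.1-fold higher number from compound 2 to compound 3 (0.05 log units; within the scatter), and lies within the scatter, so no order between these two is claimed. Compound 1 stands well apart from it, a 15-fold higher number from compound 1 to compound 3 (1.18 log units; beyond the scatter).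

Compound 4 `CN(C)CCn1cnnc1-c1cc(Oc2ccc(NC(=O)N/N=C/c3cccc(Cl)c3Cl)cc2F)ccn1` differs from compound 3 in one place: 2,3-dichlorophenyl in place of 4-fluorophenyl on a carbon with a double bond to nitrogen.

Within the data shown here, two measured steps bear on this change. Replacing 2,4-dichlorophenyl by 4-fluorophenyl gave a 15-fold higher number from compound 1 to compound 3 (1.18 log units; beyond the scatter), and replacing it by phenyl gave a 14-fold higher number from compound 1 to compound 2 (1.14 log units; beyond the scatter); both are large and point towards higher numbers when the dichlorophenyl is removed. The step from compound 3 to compound 4 runs the other way, back to a dichlorophenyl, although the entering group is 2,3-dichlorophenyl, for which no measurement exists, so the size is less secure than the measured steps. A large step towards lower numbers in this assay is expected, a 6.6-fold lower number from compound 3 to compound 4 (0.82 log units; beyond the scatter). Compound 4 is estimated at 300 nM, with a range from 100 nM to 1200 nM.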

Compound 4, half-maximal inhibitory concentration: 72 nM
Compound 4: middle estimate off by 4.2-fold (0.62 log units), on the high side; measured number outside the range, below it.
By their numbers in this assay, from the lowest: compounds 4 and 1 (each within the scatter of the next); then compounds 2 and 3 (each within the scatter of the next).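

In this assay, 2,3-dichlorophenyl on the carbon with a double bond to nitrogen gives a 28-fold lower number from compound 3 to compound 4 (1.44 log units; beyond the scatter) and a 25-fold lower number from compound 2 to compound 4 (1.39 log units; beyond the scatter), so the large gap between 2,4-dichlorophenyl and the phenyl and 4-fluorophenyl groups is not confined to one dichlorophenyl group. The two dichlorophenyl groups differ by a 1.8-fold lower number from compound 1 to compound 4 (0.26 log units; within the scatter), which lies within the scatter, so no order is claimed between them, and moving a chlorine from the one pattern to the other leaves no readable difference in this pair. No measurement available explains the gap between the dichlorophenyl compounds and the other two.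

Still open, as far as these compounds go, is whether a single chlorine, as in 2-chlorophenyl or 4-chlorophenyl, would be enough at this position, and whether methyl or trifluoromethyl could stand in for the chlorines. Also open, from the compounds shown here alone, is how a morpholine in place of the dimethylamine on the shared core would read.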